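The source may report more compounds than this note shows. Statements on the series, on what has been measured and on what is new or still open speak of the compounds shown alone.

Measured compounds:
- compound 1, `Cc1cc(C(F)(F)F)cc(NC[C@@H]2CC3(CC3)CN2C(=O)c2nc(C)sc2-c2ccccc2)n1`: 8.6
- compound 2, `Cc1cccc(NC[C@@H]2CC3(CC3)CN2C(=O)c2nc(C)sc2-c2ccccc2)n1`: 7.6

Both compounds were tested in a functional assay on HEK293 cells for antagonist activity at Orexin receptor type 2 (Homo sapiens), read by FLIPR and calcium flux; on this read-out lower numbers stand for lower potency and higher numbers for higher potency (the scale is a negative logarithm). Of the two numbers, compound 2 stands lowest; its nearest neighbour, compound 1, lies higher by a margin beyond the scatter, as the step of a number 1.00 log units lower from compound 1 to compound 2 (beyond the scatter) shows. For the measured compounds named here, that single step, a swap of trifluoromethyl for hydrogen on an aromatic carbon, is the only comparison available.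

Compound 3, `Cc1nc(C(=O)N2CC3(CC3)C[C@H]2CNc2cc(C(F)(F)F)ccn2)c(-c2ccccc2)s1`, has not yet been measured in this assay. It differs from compound 2 by the change (4-(trifluoromethyl)pyridin-2-yl in place of 6-methylpyridin-2-yl on an amine nitrogen). In plain terms, the trifluoromethyl group that compound 2 lacks returns on the pyridinyl ring, while the methyl group on that ring leaves. The step of a number 1.00 log units lower from compound 1 to compound 2 (beyond the scatter) shows that losing the trifluoromethyl cost potency, so regaining it is expected to raise the number again, though the methyl is also gone and the trifluoromethyl sits at a different place on the ring, so the recovery may be only partial.

For compound 3 the expected step is a number 0.70 log units higher from compound 2 to compound 3 (beyond the scatter), giving an estimate of 8.3, with a range from 7.6 to 8.9.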

Compound 3, negative logarithm of the antagonist equilibrium constant: 8.5
For compound 3 the middle estimate is 0.20 log units below the measured one; the range from low to high includes it.
By their numbers in this assay, from the lowest: compound 2; then compounds 3 and 1 (each within the scatter of the next).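

Removing the methyl from the pyridine ring of compound 1 leaves the number in this assay essentially unchanged (a number 0.10 log units lower from compound 1 to compound 3 (within the scatter)), so with 4-(trifluoromethyl)pyridin-2-yl on the amine nitrogen, the methyl adds nothing that can be told apart from the scatter. The swap of 6-methylpyridin-2-yl for 4-(trifluoromethyl)pyridin-2-yl changes two things at once and brings a clear gain (a number 0.90 log units higher from compound 2 to compound 3 (beyond the scatter)), and read together with the first comparison, this places the potency gain among these three compounds with the trifluoromethyl rather than the methyl. No measurement shown here explains why the trifluoromethyl matters at this position.

Going by these compounds, a ring carrying neither group, plain pyridin-2-yl, would show whether the methyl contributes anything when the trifluoromethyl is absent, and that remains open. On these data alone, it is also open whether the gain needs trifluoromethyl itself, or whether a chlorine, a nitrile or a methoxy group at the same place on the ring would give a similar number.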